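Methoxy for Methyl on a Second Core

This account rests on a few compounds, and the source may have more. Where it says the series, first, only, none or still open, it means among the compounds named here.

Compound 1 `Cc1cccc(/C=N/c2ccc(OCc3ccccc3)cc2)c1O` gives 15500 nM in an assay on isolated protein for inhibition of Amine oxidase [flavin-containing] B (Homo sapiens), read by fluorescence and Amplex Red, with stated times of 15 min and 20 min; a lower number here means a stronger inhibitor, a higher number a weaker inhibitor. Compound 2 `COc1cccc(/C=N/c2ccc(OCc3ccccc3)cc2)c1O` gives 6500 nM. Compound 3 `Cc1ccc(/C=N/c2ccc(OCc3ccccc3)cc2)c(O)c1` gives 24400 nM.

Compound 2 differs from compound 1 by methoxy in place of methyl on an aromatic carbon, and that change brought a 2.4-fold lower number from compound 1 to compound 2 (0.38 log units; beyond the scatter). Compound 3 differs from compound 1 in its core, by 2-hydroxy-4-methylphenyl in place of 2-hydroxy-3-methylphenyl on a carbon with a double bond to nitrogen, giving a 1.6-fold higher number from compound 1 to compound 3 (0.20 log units; within the scatter).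

Compound 4 `COc1ccc(/C=N/c2ccc(OCc3ccccc3)cc2)c(O)c1` has not been measured. It differs from compound 3 by methoxy in place of methyl on an aromatic carbon. This is the same kind of change as that from compound 1 to compound 2, but the place differs: there the methoxy was ortho to the hydroxy group and meta to a large group, here it is meta to the hydroxy group and para to a large group. A step like a 2.4-fold lower number from compound 1 to compound 2 (0.38 log units; beyond the scatter) is expected, so a 2.2-fold lower number from compound 3 to compound 4 (0.35 log units; beyond the scatter) is estimated, with less certainty given the different place. Compound 4 is expected to give 11000 nM, between 5000 nM and 26000 nM.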

Compound 4, half-maximal inhibitory concentration: 23600 nM
Compound 4: middle estimate off by 2.1-fold (0.33 log units), on the low side; the range from low to high includes it.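

On the second core, methoxy in place of methyl brought a 1.0-fold lower number from compound 3 to compound 4 (0.01 log units; within the scatter) in this assay, so the clear gain seen on the first core does not show up here. Even so, the two steps cannot be told apart: the same change on two cores in this assay, a 2.4-fold lower number (0.38 log units; beyond the scatter) from compound 1 to compound 2 and a 1.0-fold lower number (0.01 log units; within the scatter) from compound 3 to compound 4, 2.3-fold (0.36 log units) apart, within the scatter of two such steps

The data therefore neither show that the change carries over from one core to the other nor show that it fails to, and since the methoxy also sits in a different place in each pair, the effects of core and place stay tangled. Open, on these data alone, is what other groups in these places, such as an amine, a carboxylic acid or a longer chain like ethoxy, would do on either core.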